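The compounds below may be only part of what the source reports. "The series", "measured", "known", "first", "only" and "open" are said of these compounds alone.

Measured compounds:
compound 1 `O=C1CC(c2ccccc2OCc2ccc(F)cc2)Oc2ccccc21` — 28200 nM
compound 2 `CC(C)=CCOc1ccccc1C1CC(=O)c2ccccc2O1` — 32700 nM

Both compounds were examined in a functional assay on RAW264.7 cells (Mus musculus) for inhibition, read by Griess assay, with stated times of 1 h and 24 h; a lower number here means a stronger inhibitor, a higher number a weaker inhibitor. Compound 2 gives 32700 nM, the higher of the two numbers, with compound 1 at 28200 nM. Within the data shown here, the only measured step, a 1.2-fold higher number from compound 1 to compound 2 (0.06 log units; within the scatter), shows that exchanging one group on the ether oxygen for another left the result within the scatter.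

Compound 3 `O=C1CC(c2ccccc2O)Oc2ccccc21` is not yet measured. It differs from compound 2 in this way: hydrogen in place of 3-methylbut-2-en-1-yl on an oxygen on an aromatic ring. Among the measured compounds shown here, this is a removal rather than an exchange, and no measured pair covers it directly; the step from compound 1 to compound 2 bears on it only in showing that the ether substituent did not move the number much. The step is therefore expected to be small, in either direction, with wide uncertainty. Compound 3 is estimated at 35000 nM (range 12000 nM to 100000 nM), a step of a 1.1-fold higher number from compound 2 to compound 3 (0.03 log units; within the scatter) expected.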

Compound 3, half-maximal inhibitory concentration: 71300 nM
For compound 3 the middle estimate is 2.0-fold (0.31 log units) below the measured one, and the stated range covers the measured number.
By their numbers in this assay, from the lowest: compounds 1 and 2 (each within the scatter of the next); then compound 3.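

In this assay the group on this oxygen turns out to count once it is removed altogether: hydrogen in place of 3-methylbut-2-en-1-yl gives a 2.2-fold higher number from compound 2 to compound 3 (0.34 log units; beyond the scatter) and hydrogen in place of 4-fluorobenzyl gives a 2.5-fold higher number from compound 1 to compound 3 (0.40 log units; beyond the scatter) and both steps are modest but beyond the scatter. Compound 1 and compound 2 stay within the scatter of each other, so these two different ether groups read alike, while compound 3, with its free hydroxy, is the weakest inhibitor of the three. Nothing available explains why removing the group raises the number.

Going by these compounds, whether a methyl group, a longer chain or a chain carrying an amine on this oxygen would read like compound 1 and compound 2 stays open. With only two ether groups shown, how broadly an ether here holds the number also remains unknown.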